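The compounds below may be only part of what the source reports. "The series", "measured", "known", "first", "only" and "open" are said of these compounds alone.

Of the compounds shown here, two have been measured so far in a functional assay on HEK293 cells for agonist activity at D(4) dopamine receptor (Homo sapiens), read by FLIPR; a higher number here means a larger maximal response, a lower number a smaller maximal response. Compound 1, `O=C(CN1CCC(c2cccc[n+]2[O-])CC1)Nc1cccc(F)c1`, gives 70%. Among the measured compounds shown here, compound 2, `CC(C)Oc1cccc(NC(=O)CN2CCC(c3cccc[n+]3[O-])CC2)c1`, gives 48%, the lower of the two numbers, and the only measured step, a number 22 percentage points lower from compound 1 to compound 2 (beyond the scatter), came from putting isopropoxy in place of fluoro on an aromatic carbon. Compound 3, `O=C(CN1CCC(c2cccc[n+]2[O-])CC1)Nc1cccc(-c2ccccc2)c1`, is the compound now in question, and it differs from compound 2 in one place: phenyl in place of isopropoxy on an aromatic carbon. For the measured compounds named here, only the one measured step bears on this position, and it moved the read-out modestly downward when fluoro was exchanged for isopropoxy. Going by the values given here, no measured pair shows what a phenyl does at that position, so that step is a loose guide at best. On this basis compound 3 is expected to stay near compound 2 or fall somewhat, with a number 8 percentage points lower from compound 2 to compound 3 (within the scatter) as the expected step. The estimate for compound 3 in this assay is 40%, expected to lie between 20% and 65%. The band is wide. A single step cannot fix either the direction or the size of the change with any confidence.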

Compound 3, largest response reached (reported as efficacy), in percent of the reference or control that the assay uses: 75%
For compound 3 the middle estimate is 35 percentage points below the measured one; the whole stated range lies below it.
By their numbers in this assay, from the lowest: compound 2; then compounds 1 and 3 (each within the scatter of the next).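

In this assay, the lower response seen with isopropoxy does not carry over to every larger group on this aromatic carbon, meta to a large group: phenyl in place of isopropoxy gives a number 27 percentage points higher from compound 2 to compound 3 (beyond the scatter) and so restores a high number. Phenyl in place of fluoro gives a number 5 percentage points higher from compound 1 to compound 3 (within the scatter) and so does not separate the two, even though one is a single halogen atom and the other a whole six-membered aromatic ring. Isopropoxy alone stands apart among these three groups, and since phenyl has more heavy atoms than isopropoxy yet the higher number, the heavy-atom count of the group does not by itself set the maximal response in these compounds.

Nothing available explains why isopropoxy differs from fluoro and phenyl. Going by these compounds, it remains open whether a methoxy, which keeps the oxygen on the ring with a shorter chain, or an amine or a carboxylic acid on the same carbon would fall with isopropoxy or stand with fluoro and phenyl.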